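Methyl for Methoxy on the Benzylidene Aryl of Compound 1

A few compounds are considered here, and "the series" means these few. Any claim that something is new, unique, unknown or untested is made for them only; others in the source may bear on it.

Measured so far:
compound 1, `COc1ccc(/C=C2/N=C(c3ccccc3)N(C(=O)c3ccc(C)cc3)NC2=O)cc1`, 30 mg/kg
compound 2, `O=C1NN(C(=O)c2ccccc2Cl)C(c2ccccc2)=N/C1=C/c1ccccc1Cl`, 100 mg/kg
compound 3, `COc1ccc(/C=C2/N=C(c3ccccc3)N(C(=O)c3ccc(Cl)cc3)NC2=O)cc1`, 300 mg/kg

The read-out throughout is a functional assay on the whole organism (strain albino) with Mus musculus as the target, with a stated time of 4 h; a lower number here means that less compound is needed, a higher number that more compound is needed for the effect. Of the three measured compounds, compound 1 gives the lowest number, and compound 2 stands nearest to it; compound 3 lies furthest away, reached from compound 1 by a 10-fold higher number from compound 1 to compound 3 (1.00 log units; beyond the scatter), a change on a different aromatic ring from the one considered here.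

The unmeasured compound 4 has the structure `Cc1ccc(/C=C2/N=C(c3ccccc3)N(C(=O)c3ccc(C)cc3)NC2=O)cc1`. It differs from compound 1 in one place: methyl in place of methoxy on an aromatic carbon.

Within the data shown here, no measured step changes this position: the only recorded step, from compound 1 to compound 3, exchanges groups on the benzoyl ring, and compound 2 differs from compound 1 in several places at once, so its value speaks to nothing in isolation. With nothing bearing directly on the change, a step no larger than the usual scatter is expected, with some allowance for drift in either direction. For compound 4 the expected result is 45 mg/kg, within 15 mg/kg to 150 mg/kg. This estimate amounts to a 1.5-fold higher number from compound 1 to compound 4 (0.18 log units; within the scatter).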

Compound 4, dose for half-maximal effect: 30 mg/kg
Compound 4: the middle estimate sits 1.5-fold (0.18 log units) above what was measured; low and high end bracket the measured number.
By their numbers in this assay, from the lowest: compounds 1 and 4 (each within the scatter of the next); then compound 2; then compound 3.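

In this assay, among these compounds, the exchange of 4-methoxyphenyl for 4-methylphenyl gives no change at the digits printed from compound 1 to compound 4 (within the scatter) and so provides the first reading at this position: the oxygen of the methoxy group, with its one hydrogen-bond acceptor, can go without a shift this read-out can separate. The step stands in contrast to the exchange on the benzoyl ring, where chloro in place of methyl gives a 10-fold higher number from compound 1 to compound 3 (1.00 log units; beyond the scatter) in the same read-out. Nothing available explains why the two groups read alike here.

On these data alone, whether this position accepts groups other than these two stays open, since this single pair says nothing about a hydroxy group, an amine or a carboxylic acid there. Also open, as far as these compounds go, is whether methyl and methoxy would still read alike with the chloro group of compound 3 on the benzoyl ring.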